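Adding Fluoro to Compound 1: An Expected Cytotoxicity

The source may hold more compounds than are shown below. What is called first, only, known or untested is meant among the compounds shown, and "the series" means these compounds.

Measured compounds:
compound 1 `COc1nc2ccc(Br)cc2cc1C(c1ccccc1)n1cc(-c2ccccc2)nn1` — 30.1%
compound 2 `CCCCCc1cn(C(c2ccccc2)c2cc3cc(Br)ccc3nc2OC)nn1` — 5.07%

In an ADME assay on PANC-1 cells (Homo sapiens) for cytotoxicity, read by sulforhodamine B assay, with a stated time of 48 h, tested at 10 uM (a higher number here means more inhibition at the concentration tested (going by the name of the read-out), a lower number less inhibition), compound 1 gives 30.1%, the highest of the two numbers available. Compound 2 gives 5.07%. Going by the values given here, the one measured step, a number 25 percentage points lower from compound 1 to compound 2 (beyond the scatter), comes with pentyl in place of phenyl on an aromatic carbon, a replacement of the whole ring by a chain.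

Compound 3 `COc1nc2ccc(Br)cc2cc1C(c1ccccc1)n1cc(-c2cccc(F)c2)nn1` differs from compound 1 by fluoro in place of hydrogen on an aromatic carbon. Among the compounds with values here, no measured step tests a single fluoro added to that ring: the step from compound 1 to compound 2 concerns the loss of the phenyl itself, not a substituent on it, so it bears only loosely on the change at hand. Compound 3 is therefore expected to land close to compound 1, with a number 1.9 percentage points higher from compound 1 to compound 3 (within the scatter) judged to stay within the usual scatter. The estimate for compound 3 is 32%, in a range from 10% to 55%.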

Compound 3, a percentage reported as inhibition, at one concentration (the size of the read-out at that concentration, not a potency): 15.5%
Compound 3: middle estimate off by 16.5 percentage points, on the high side, within the range that was stated.
By their numbers in this assay, from the lowest: compound 2; then compound 3; then compound 1.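

In this assay the phenyl ring of the core of compound 1 proves sensitive to a single added atom: fluoro in place of hydrogen, meta to a large group, gives a number 14.6 percentage points lower from compound 1 to compound 3 (beyond the scatter) and so takes away part of the inhibition. The earlier compounds had shown a change of this kind only when the whole ring gave way to a chain, yet the 3-fluorophenyl compound still keeps an edge over the pentyl compound, with a number 10.4 percentage points higher from compound 2 to compound 3 (beyond the scatter) between them. Nothing available accounts for the effect of the fluoro.

As far as these compounds go, whether fluoro elsewhere on the ring would lower the number in the same way remains open. So does whether a chlorine, a methoxy group or an amine in this same place would follow fluoro or part from it.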